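This account rests on a few compounds, and the source may have more. Where it says the series, first, only, none or still open, it means among the compounds named here.

In a functional assay on ONS-76 cells (Homo sapiens) for cytotoxicity, read by MTT assay, with a stated time of 72 h (a higher number here means a weaker inhibitor, a lower number a stronger inhibitor), compound 1 (`COc1cc(N(C)C(=O)c2cccc([N+](=O)[O-])c2)cc(OC)c1OC`) is known only as a limit, >= 125000 nM, and not as a number. Compound 2 (`COc1cc(NC(=O)c2cccc([N+](=O)[O-])c2)cc(OC)c1OC`) is likewise known only as a limit, >= 125000 nM. The record for this series therefore shows (the limit of >= 125000 nM in this assay, at which 2 of the 2 values shown sit). Compound 3 (`COc1cc(N(C)C(=O)c2ccccc2)cc(OC)c1OC`) departs from compound 1 elsewhere: hydrogen in place of nitro on an aromatic carbon. For the measured compounds named here, the one measured step, a step that the two limits leave unreadable from compound 1 to compound 2, concerns the amide-type nitrogen rather than this aromatic carbon, and it offers no size to carry over. Compound 1 provides only its limit, >= 125000 nM, as a starting point, so no step beyond the scatter is expected for compound 3 in this assay. The expected size is a number no higher from compound 1 to compound 3 (the limit leaves the size open). For compound 3 the estimate is 125000 nM, with an expected range from 50000 nM to 250000 nM.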

Compound 3, half-maximal inhibitory concentration: >= 125000 nM
Compound 3 gave a limit, no number; the forecaster's own chance of this, stated with the estimate: 75%; the middle value sits exactly at the limit.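

For the compounds shown here, compound 3, like compound 1, is known only as a limit, so no step from compound 1 to compound 3 can be read in this assay. All the compounds shown stand at one limit: the limit of >= 125000 nM in this assay, at which 3 of the 3 values shown sit.

The compounds shown leave open what change on the shared core, if any, would give a measurable value in this assay.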